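Swapping isopropyl for trifluoromethyl: what to expect

A few compounds are considered here, and "the series" means these few. Any claim that something is new, unique, unknown or untested is made for them only; others in the source may bear on it.

Compound 1 `CC(C)(C)c1ccc(/C=C(/C(=O)Nc2ccc3c(c2)OCCO3)c2ccccc2)cc1`: > 4000 nM
Compound 2 `CC(C)c1ccc(/C=C/C(=O)Nc2ccc3c(c2)OCCO3)cc1`: 55 nM

Of the compounds shown here, two have been measured in a functional assay on CHO cells for inhibition of transient receptor potential cation channel subfamily V member 1 (Homo sapiens); on this read-out higher numbers stand for weaker inhibition and lower numbers for stronger inhibition. Compound 1 gives > 4000 nM in this assay, and that figure is a limit of the assay, not a number. Compound 2 gives 55 nM in this assay. Compound 2 therefore stands as the only real number among the results shown; the one other result sits at the limit (the limit of > 4000 nM in this assay, at which 1 of the 2 values shown sits). For the measured compounds named here, no two measured compounds differ in just one place, so no measured step shows what a single swap does here.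

Compound 3 `O=C(/C=C/c1ccc(C(F)(F)F)cc1)Nc1ccc2c(c1)OCCO2` is still unmeasured. It differs from compound 2 in one place: trifluoromethyl in place of isopropyl on an aromatic carbon. Going by the values given here, with no measured step of this kind to lean on, the expected step, a 1.1-fold higher number from compound 2 to compound 3 (0.04 log units; within the scatter), should stay within the usual scatter, in no clear direction. Compound 3 is therefore estimated at 60 nM in this assay, with a likely range from 15 nM to 250 nM.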

Compound 3, half-maximal inhibitory concentration: 46 nM
The estimate for compound 3 lay 1.3-fold (0.12 log units) above the measured number; low and high end bracket the measured number.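

In this assay, for the compounds shown here, the first measured single swap gives a 1.2-fold lower number from compound 2 to compound 3 (0.08 log units; within the scatter), a step that lies within the scatter. On this aromatic carbon, para to a large group, the assay therefore does not tell trifluoromethyl from isopropyl, even though the two groups differ in their atoms. The results shown hold no measurement that bears on why the two groups read alike.

On these data alone, both groups count no hydrogen-bond donors and no hydrogen-bond acceptors, so it remains open whether an amine, a carboxylic acid or a longer chain on the same carbon would read the same way. Compound 1 gives > 4000 nM, which is a limit of the assay and not a number, and it differs from the other compounds in more than one place, so it leaves open what any single change to the shared core would do.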